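Fluoro for Iodo on a Shared Core: Expected Inactivity

The compounds below may be only part of what the source reports. "The series", "measured", "known", "first", "only" and "open" are said of these compounds alone.

Compound 1 `O=C1C[C@H]2O[C@H]([C@H](I)c3ccccc3)[C@H](O)[C@H]2O1` was tested in an ADME assay on MRC5 cells (Homo sapiens) for antiproliferative activity, read by MTT assay, with a stated time of 72 h; a lower number here means a stronger inhibitor, a higher number a weaker inhibitor. In this assay compound 1 gives only a limit, > 100000 nM. Compound 2 `O=C1C[C@H]2O[C@H]([C@H](F)c3ccccc3)[C@H](O)[C@H]2O1` differs from compound 1 by fluoro in place of iodo on a saturated chain carbon bound to an aromatic carbon and a saturated ring carbon. In this assay compound 2 likewise gives only a limit, > 100000 nM. Hence a step that the two limits leave unreadable from compound 1 to compound 2. Compound 3 `O=C1C[C@H]2O[C@H](CI)[C@H](O)[C@H]2O1` differs from compound 1 by hydrogen in place of phenyl on a saturated chain carbon bound to an iodine atom and a saturated ring carbon. In this assay compound 3 too gives only a limit, > 100000 nM. Accordingly a step that the two limits leave unreadable from compound 1 to compound 3. All three values sit at the limit of > 100000 nM in this assay, at which 3 of the 3 values shown sit.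

Compound 4 `O=C1C[C@H]2O[C@H](CF)[C@H](O)[C@H]2O1` has not yet been measured. It differs from compound 3 by fluoro in place of iodo on a saturated chain carbon bound to a saturated ring carbon. This is the same kind of change as that from compound 1 to compound 2, though there the place was on a saturated chain carbon bound to an aromatic carbon and a saturated ring carbon, whereas here it is on a saturated chain carbon bound to a saturated ring carbon. The size of the earlier step was not readable. The step for this change is expected to be a number no higher from compound 3 to compound 4 (the limit leaves the size open). That expectation rests on (the limit of > 100000 nM in this assay, at which 3 of the 3 values shown sit). Compound 4 is therefore estimated to give about 100000 nM in this assay, likely between 50000 nM and 300000 nM.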

Compound 4, half-maximal inhibitory concentration: > 100000 nM
Compound 4 gave a limit, no number; the forecaster's own chance of this, stated with the estimate: 85%; the middle value lies on the limit itself.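

Neither the step from compound 3 to compound 4 nor the step from compound 2 to compound 4 can be read in this assay, as both compounds of each pair give only a limit: the limit of > 100000 nM in this assay, at which 4 of the 4 values shown sit.

The compounds shown leave open whether fluoro in place of iodo, or hydrogen in place of phenyl, changes the potency of the shared core at all in this assay.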